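Adding a methoxy to the dimethoxyphenyl arm: compound 3

This account rests on a few compounds, and the source may have more. Where it says the series, first, only, none or still open, it means among the compounds named here.

Compound 2 `COc1ccc(C2CC(c3cc(Cl)c(C)cc3O)=NN2c2ccc(S(N)(=O)=O)cc2)cc1OC` stands at 19700 nM in a functional assay on A549 cells (Homo sapiens) for antiproliferative activity, with a stated time of 48 h; on this read-out higher numbers stand for weaker inhibition of growth and lower numbers for stronger inhibition of growth; the other of the two numbers shown belongs to compound 1 `Cc1cc(O)c(C2=NN(c3ccc(S(N)(=O)=O)cc3)C(c3ccccc3Cl)C2)cc1Cl`, which gives 19300 nM, and the step of a 1.0-fold higher number from compound 1 to compound 2 (0.01 log units; within the scatter) is within the scatter. Compound 3 `COc1ccc(C2CC(c3cc(Cl)c(C)cc3O)=NN2c2ccc(S(N)(=O)=O)cc2)c(OC)c1OC` differs from compound 2 by methoxy in place of hydrogen on an aromatic carbon. For the measured compounds named here, no measured step touches the same position; the one step in hand exchanged the whole aryl group on the saturated ring carbon and moved the number by no more than the scatter, so that arm appears to tolerate a change of this kind without a visible effect on growth inhibition. No other guidance exists for the added methoxy. For compound 3 no step beyond the scatter in this assay is therefore expected, the estimate being a 1.0-fold higher number from compound 2 to compound 3 (0.01 log units; within the scatter). Compound 3 is estimated at 20000 nM, with a range from 9000 nM to 45000 nM.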

Compound 3, concentration for total growth inhibition: 13800 nM
Beside the measured number, compound 3's estimate is 1.4-fold (0.16 log units) above it; measured number inside the range.
By their numbers in this assay, from the lowest: compounds 3, 1 and 2 (each within the scatter of the next).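

In this assay, for the compounds shown here, methoxy in place of hydrogen on the aromatic carbon ortho to a large group gives a step (a 1.4-fold lower number from compound 2 to compound 3 (0.15 log units; within the scatter)) that stays within the scatter, so this position, untouched by the earlier compounds, accepts the group with no effect that can be read. Exchanging the whole arm gives the same reading (a 1.4-fold lower number from compound 1 to compound 3 (0.15 log units; within the scatter)), and 2-chlorophenyl, 3,4-dimethoxyphenyl and 2,3,4-trimethoxyphenyl on the saturated ring carbon cannot be told apart in these three compounds. Nothing available bears on why this arm shows so little response.

As far as these compounds go, whether an amine or a carboxylic acid on this arm would move the number beyond the scatter remains open. From the compounds shown here alone, all three compounds share the rest of the core, so its contribution also remains open.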